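Working notes: a repeated chloro-for-hydrogen step in one series

The source may hold more compounds than are shown below. What is called first, only, known or untested is meant among the compounds shown, and "the series" means these compounds.

Measured so far:
compound 1 `ClCc1ccc(Cn2cnc3c(Cl)ncnc32)cc1`: 1000 nM
compound 2 `ClCc1cccc(Cn2cnc3ncnc(Cl)c32)c1`: 3090 nM
compound 3 `ClCc1ccc(Cn2cnc3c(Cl)nc(Cl)nc32)cc1`: 2040 nM

All three values come from a functional assay on LOX IMVI cells (Homo sapiens) for cytotoxicity, read by sulforhodamine B assay, with a stated time of 48 h; a higher number here means a weaker inhibitor of growth, a lower number a stronger inhibitor of growth. Compound 3 differs from compound 1 by chloro in place of hydrogen on an aromatic carbon, and that change gave a 2.0-fold higher number from compound 1 to compound 3 (0.31 log units; beyond the scatter). Compound 2 and compound 1 have the same atoms joined differently; the difference between the two cores is not broken down here. Compound 2 shows the highest number of the three, beyond the scatter only against compound 1.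

Compound 4 `ClCc1cccc(Cn2cnc3nc(Cl)nc(Cl)c32)c1` has not been measured. It differs from compound 2 by chloro in place of hydrogen on an aromatic carbon, the same change as from compound 1 to compound 3, at a place described in the same words. Within the data shown here, the step from compound 2 to compound 4 in this assay is expected to be a 1.9-fold higher number from compound 2 to compound 4 (0.29 log units; within the scatter), a size resting on the one measured instance and therefore uncertain. Compound 4 is expected near 6000 nM, between 3000 nM and 12000 nM.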

Compound 4, concentration for 50% growth inhibition: 230 nM
For compound 4 the middle estimate is 26-fold (1.42 log units) above the measured one, outside the stated range (below it).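

In this assay, chloro in place of hydrogen on an aromatic carbon gives a 13-fold lower number from compound 2 to compound 4 (1.13 log units; beyond the scatter), so the step seen on the core of compound 1 does not carry over to the core of compound 2 in size or in direction: the same change on two cores in this assay, a 2.0-fold higher number (0.31 log units; beyond the scatter) from compound 1 to compound 3 and a 13-fold lower number (1.13 log units; beyond the scatter) from compound 2 to compound 4, 27-fold (1.44 log units) apart, beyond the scatter of two such steps. This shows that, for these two pairs, a step read on one core cannot stand in for the same change on the other. It does not show what separates the two cores, and two instances give no rule for any further core.

The compounds shown leave open what an amine or a methoxy group in place of the chloro would give on each core. They also leave open whether the two cores would part in the same way in another cell line.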